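A few compounds are considered here, and "the series" means these few. Any claim that something is new, unique, unknown or untested is made for them only; others in the source may bear on it.

Measured so far in a functional assay on DU-145 cells (Homo sapiens) for inhibition, read by trypan blue exclusion, with a stated time of 96 h; on this read-out lower numbers stand for stronger inhibition of growth and higher numbers for weaker inhibition of growth:
compound 1 `O=C(/C(=C\c1ccc([N+](=O)[O-])c(O)c1)SCc1ccc(Br)cc1)c1ccc([N+](=O)[O-])cc1`: 1000 nM
compound 2 `O=C(/C(=C\c1ccc([N+](=O)[O-])c(O)c1)SCc1ccc(Br)cc1)c1ccc([N+](=O)[O-])c(Cl)c1`: 1000 nM
compound 3 `O=C(/C(=C\c1ccc([N+](=O)[O-])c(O)c1)SCc1ccc(Br)cc1)c1ccc(Br)cc1`: 10000 nM

Compound 3 has the highest number of the three. Compound 4 `O=C(/C(=C\c1ccc([N+](=O)[O-])c(O)c1)SCc1ccc(Br)cc1)C1CCNC1` is not yet measured. In it, pyrrolidin-3-yl takes the place of 4-bromophenyl on a carbonyl carbon (pyrrolidin-3-yl in place of 4-bromophenyl on a carbonyl carbon).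

Two measured steps alter the group on that carbonyl carbon (a 10-fold higher number from compound 1 to compound 3 (1.00 log units; beyond the scatter)) and (a 10-fold higher number from compound 2 to compound 3 (1.00 log units; beyond the scatter)). Both are modest and beyond the scatter. The third step (no change at the digits printed from compound 1 to compound 2 (within the scatter)) stays within it. None of the three puts a non-aromatic ring at this place, so the guide is indirect and the range must stay wide.

A modest move towards a lower number is expected, as compound 3 already stands at the top of the series (10000 nM). In this assay the expected step is (a 3.3-fold lower number from compound 3 to compound 4 (0.52 log units; beyond the scatter)) and remains an estimate. For compound 4 the estimated value is 3000 nM with an expected range from 500 nM to 15000 nM in this estimate.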

Compound 4, concentration for 50% growth inhibition: > 100000 nM
Compound 4: no number, only a limit (the forecaster's own chance of this, stated with the estimate: 15%); middle value at least 33-fold (1.52 log units) away from the limit.
By their numbers in this assay, from the lowest: compounds 1 and 2 (each within the scatter of the next); then compound 3. At a limit, above all of these: compound 4.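

In this assay, compound 4 carries a limit of the assay and not a number: the limit of > 100000 nM in this assay, at which 1 of the 4 values shown sits. Even read against that limit, pyrrolidin-3-yl on the carbonyl carbon gives an at least 10-fold higher number from compound 3 to compound 4 (1.00 log units; beyond the scatter), and the comparisons with the two nitro-bearing aromatic groups give an at least 100-fold higher number from compound 2 to compound 4 (2.00 log units; beyond the scatter) and an at least 100-fold higher number from compound 1 to compound 4 (2.00 log units; beyond the scatter). The earlier compounds shown here varied only the substituents on a six-membered aromatic ring here, whereas compound 4 shows that a five-membered non-aromatic ring with a ring nitrogen in this place takes growth inhibition out of the measurable range.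

This single change removes the aromatic ring and brings in the ring nitrogen together, so the two cannot be separated. A cyclopentyl ring, or a pyrrolidine with an acetyl group on its nitrogen, would tell them apart.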